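This account rests on a few compounds, and the source may have more. Where it says the series, first, only, none or still open, it means among the compounds named here.

Measured so far in a functional assay on Bel-7402 cells (Homo sapiens) for cytotoxicity, read by MTT assay; on this read-out higher numbers stand for weaker inhibition and lower numbers for stronger inhibition:
Compound 1 `COc1ccc(/C=C/C(=O)c2sc(Nc3ccc(Cl)cc3)nc2C)cc1` gives > 25000 nM, which is a limit of the assay and not a number.
Compound 2 `Cc1nc(Nc2ccc(Cl)cc2)sc1C(=O)/C=C/c1ccccc1` gives > 25000 nM, again a limit of the assay.
Compound 3 `COc1cccc(/C=C/C(=O)c2sc(Nc3cccc(C)c3)nc2C)c1` gives > 25000 nM, also a limit of the assay.

Compound 3 therefore stands nowhere definite on this assay: its value is only a limit, and every value shown so far sits at that same limit (the limit of > 25000 nM in this assay, at which 3 of the 3 values shown sit). Compound 4 `COc1cccc(/C=C/C(=O)c2sc(Nc3ccc(Cl)cc3)nc2C)c1` differs from compound 3 in one place: 4-chlorophenyl in place of 3-methylphenyl on a nitrogen on an aromatic ring. Among the compounds with values here, no measured step touches that place. Within the data shown here, the only measured step, a step that the two limits leave unreadable from compound 1 to compound 2, alters a different part of the molecule and is itself unreadable between two limits, so it gives no size to carry over. What can be said is that compound 1 already carries the 4-chlorophenyl group on the nitrogen that compound 4 will carry, and compound 1 sits at the limit as well. Compound 4 is accordingly expected to give 30000 nM, within a range from 10000 nM to 100000 nM. The expected step that the limit leaves unreadable from compound 3 to compound 4 is thus none beyond the scatter, and most likely the assay will again report only a limit for compound 4.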

Compound 4, half-maximal inhibitory concentration: > 25000 nM
Compound 4 was reported as a limit; the forecaster's own chance of this, stated with the estimate: 85%; the middle value lies beyond the limit too.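

Within the data shown here, compound 4, like compound 1, compound 2 and compound 3, is reported only as a limit in this assay, so no step among them can be read: the limit of > 25000 nM in this assay, at which 4 of the 4 values shown sit.
The compounds shown leave open whether any change to the shared core would give a measured number, and how large any such step would be.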